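Diol side chain in a series at the assay limit

A few compounds are considered here, and "the series" means these few. Any claim that something is new, unique, unknown or untested is made for them only; others in the source may bear on it.

Three amines on the shared core have been read in an ADME assay on MT4 cells (Homo sapiens) for cytotoxicity, read by MTT assay, with a stated time of 5 days; a higher number here means that more compound is tolerated, a lower number that less compound is tolerated. Compound 1 (`CCCCCNc1cc(Oc2c(OC)cc3cc(C#N)ccc3c2OC)nc(Nc2ccc(C#N)cc2)n1`) gives > 125000 nM, which is a limit. Compound 2 (`COc1cc2cc(C#N)ccc2c(OC)c1Oc1cc(NC(C)(C)C)nc(Nc2ccc(C#N)cc2)n1`) gives > 125000 nM, also a limit. Compound 3 (`COc1cc2cc(C#N)ccc2c(OC)c1Oc1cc(NC2CCCCC2)nc(Nc2ccc(C#N)cc2)n1`) gives > 125000 nM, again a limit. Compound 3 therefore has no number of its own, only (the limit of > 125000 nM in this assay, at which 3 of the 3 values shown sit).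

Compound 4 (`COc1cc2cc(C#N)ccc2c(OC)c1Oc1cc(NCC(O)CO)nc(Nc2ccc(C#N)cc2)n1`) follows from compound 3 by 2,3-dihydroxypropyl in place of cyclohexyl on a nitrogen on an aromatic ring.

For the measured compounds named here, the steps that bear on this change the group on the same nitrogen: a step that the two limits leave unreadable from compound 1 to compound 2, a step that the two limits leave unreadable from compound 1 to compound 3 and a step that the two limits leave unreadable from compound 2 to compound 3. Going by the values given here, none gives a size, and no measured compound carries 2,3-dihydroxypropyl. Resting on compound 3 at > 125000 nM, a limit, no step beyond the scatter is expected in this assay, and another limit is the likeliest report. The expected step is an at least 1.1-fold lower number from compound 3 to compound 4 (0.05 log units; that floor lies within the scatter). For compound 4 the estimate is 110000 nM, with an expected range from 40000 nM to 130000 nM.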

Compound 4, half-maximal cytotoxic concentration: 29500 nM
Beside the measured number, compound 4's estimate is 3.7-fold (0.57 log units) above it, outside the stated range (below it).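

In this assay this nitrogen proves able to move the read-out, with 2,3-dihydroxypropyl in place of the earlier carbon-only groups giving an at least 4.2-fold lower number from compound 3 to compound 4 (0.62 log units; beyond the scatter) and, against the two other amines, an at least 4.2-fold lower number from compound 2 to compound 4 (0.62 log units; beyond the scatter) as well as an at least 4.2-fold lower number from compound 1 to compound 4 (0.62 log units; beyond the scatter). Each of these steps starts from a limit, so each gives only a minimum size. Among the amines shown, only the diol side chain gives a number and not a limit: the limit of > 125000 nM in this assay, at which 3 of the 4 values shown sit.

The steps among compound 1, compound 2 and compound 3 cannot be read, which leaves pentyl, tert-butyl and cyclohexyl unranked. Also open, from the compounds shown here alone, is whether this step needs both hydroxyl groups, which a 2-hydroxyethyl or 3-hydroxypropyl group on the same nitrogen would test, and whether a carboxylic acid or a second amine on the chain would give a similar number.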